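The source may hold more compounds than are shown below. What is called first, only, known or untested is meant among the compounds shown, and "the series" means these compounds.

Measured so far in a functional assay on a cell-free system (plasma, Homo sapiens) for inhibition; a higher number here means a weaker inhibitor, a lower number a stronger inhibitor:
Compound 1 `COc1cc(/C=C/C(=O)Nc2nccs2)ccc1OC(C)=O` gives 25500 nM
Compound 2 `CC(=O)Oc1cccc(/C=C/C(=O)Nc2nccs2)c1` gives 35500 nM

Only these two values are available. Compound 1 (25500 nM) and compound 2 (35500 nM) lie within the usual scatter of each other, so the numbers do not separate them in this assay. Among the measured compounds shown here, compound 2 therefore stands level with the only other measured compound.

Still unmeasured is compound 3 `CC(=O)Oc1ccc(/C=C/C(=O)Nc2nccs2)cc1OC(C)=O` which differs from compound 2 by acetoxy in place of hydrogen on an aromatic carbon. The entering group sits ortho to an acetoxy group and para to a large group.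

For the measured compounds named here, no measured pair differs in one place, so the data give no direct guide to the size of this change. A modest move toward a lower number is expected, not far beyond the scatter. In this assay the step expected is a 2.4-fold lower number from compound 2 to compound 3 (0.37 log units; beyond the scatter) and it remains an estimate. For compound 3 the estimated value is 15000 nM with an expected range from 5000 nM to 40000 nM for four of five measurements.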

Compound 3, half-maximal inhibitory concentration: 75600 nM
Compound 3: the middle estimate sits 5.0-fold (0.70 log units) below what was measured, outside the stated range (above it).
By their numbers in this assay, from the lowest: compounds 1 and 2 (each within the scatter of the next); then compound 3.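

In this assay, putting a second acetoxy group on the aromatic carbon ortho to an acetoxy group weakens inhibition: acetoxy in place of hydrogen gives a 2.1-fold higher number from compound 2 to compound 3 (0.33 log units; beyond the scatter), a modest step beyond the scatter. The same carbon can also be read from the methoxy side, where acetyl in place of methyl on the oxygen gives a 3.0-fold higher number from compound 1 to compound 3 (0.47 log units; beyond the scatter), again modest and beyond the scatter, so among these three compounds acetoxy at this place carries the highest number, whether it replaces hydrogen or methoxy. The compounds shown come with no separate measurement that would account for this rise.

As far as these compounds go, it remains open whether the higher number belongs to acetoxy specifically or would also appear with a hydroxyl group, a fluorine atom or an amine on the same carbon. Also open, from the compounds shown here alone, is how the numbers would move if the acetoxy group shared by all three compounds gave way to a hydroxyl group or a longer ester chain.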